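Amino in place of fluoro: notes on the series

A few compounds are considered here, and "the series" means these few. Any claim that something is new, unique, unknown or untested is made for them only; others in the source may bear on it.

Among the compounds with values here, in a functional assay on MCF7 cells (Homo sapiens) for cytotoxicity, read by fluorescence and resazurin assay, with a stated time of 72 h (on this read-out lower numbers stand for stronger inhibition and higher numbers for weaker inhibition), compound 1 (`Nc1nc(Nc2ccc(S(N)(=O)=O)cc2)sc1C(=O)c1ccccc1[N+](=O)[O-]`) gives 3100 nM and compound 2 (`Nc1nc(Nc2ccc(S(N)(=O)=O)cc2)sc1C(=O)c1cccc(F)c1`) gives 1300 nM as the lower of the two numbers so far. The next step leads to compound 3 (`Nc1cccc(C(=O)c2sc(Nc3ccc(S(N)(=O)=O)cc3)nc2N)c1`), with amino in place of fluoro on an aromatic carbon, meta to a large group (amino in place of fluoro on an aromatic carbon). Within the data shown here, the one measured step that bears on this change is a 2.4-fold lower number from compound 1 to compound 2 (0.38 log units; beyond the scatter) and it is modest, though beyond the scatter. That step put 3-fluorophenyl in place of 2-nitrophenyl on the same carbonyl carbon, so it concerns the same part of the molecule but a different substitution. Among the measured compounds shown here, no compound carrying an amino group has a measured number yet, so the direction rests on little evidence. A small move toward a higher number is assumed, no larger than the measured step. The expected change is a 1.4-fold higher number from compound 2 to compound 3 (0.14 log units; within the scatter) on this reasoning. In this assay compound 3 is estimated at 1800 nM within an expected range of 600 nM to 5000 nM for repeat measurements.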

Compound 3, half-maximal inhibitory concentration: > 10000 nM
Compound 3: only a limit was reported; the forecaster's own chance of this, stated with the estimate: 5%; at least 5.5-fold (0.74 log units) between middle value and limit.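

In this assay compound 3 gives > 10000 nM as a limit of the assay and not a number. The change from 3-fluorophenyl to 3-aminophenyl proves far from neutral at this aromatic carbon, with an at least 7.6-fold higher number from compound 2 to compound 3 (0.88 log units; beyond the scatter) and, against the 2-nitrophenyl group, an at least 3.2-fold higher number from compound 1 to compound 3 (0.50 log units; beyond the scatter), so the 3-aminophenyl compound sits on the weaker side of both earlier compounds, which the step between those two alone could not show. On these data alone, both step sizes are only lower bounds, and the full size of the change stays unknown, as both rest on one reading: the limit of > 10000 nM in this assay, at which 1 of the 3 values shown sits.

Open, as far as these compounds go, is whether the loss belongs to the amino group in particular or would follow from other replacements of fluoro at this carbon, which a hydroxyl, methoxy or acetamide group in the same place would help to separate. Also open, from the compounds shown here alone, is whether an amino group placed elsewhere on this phenyl ring would behave the same way, and how far compound 3 actually lies past the limit of the assay.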